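Substituent swap on the anilino ring: ethyl to acetyl(methyl)amino

The source may hold more compounds than are shown below. What is called first, only, known or untested is meant among the compounds shown, and "the series" means these compounds.

Of the compounds shown here, three of the shared core have been measured in a functional assay for inhibition, with Homo sapiens as the target; on this read-out lower numbers stand for stronger inhibition and higher numbers for weaker inhibition. Compound 1 `Fc1ccc(Nc2nccc(-c3ccncc3)n2)cc1` gives 1900 nM, compound 2 `CC(=O)N(C)c1ccc(Nc2nccc(-c3cccnc3)n2)cc1` gives 900 nM, and compound 3 `CCc1ccc(Nc2nccc(-c3ccncc3)n2)cc1` gives 7700 nM. Among the measured compounds shown here, compound 3 stands highest of the three, beyond the scatter from both others; the single measured step that reaches it is a 4.1-fold higher number from compound 1 to compound 3 (0.61 log units; beyond the scatter).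

Compound 4 `CC(=O)N(C)c1ccc(Nc2nccc(-c3ccncc3)n2)cc1` is not yet measured. It differs from compound 3 in one place: acetyl(methyl)amino in place of ethyl on an aromatic carbon. For the measured compounds named here, no measured step covers this exact change on the core of compound 3. Compound 2 carries the same acetyl(methyl)amino group on a core that differs elsewhere, and compound 2 at 900 nM sits well under compound 3; compound 1, the fluoro analogue, gives 1900 nM. Both measured values for other substituents lie below that of compound 3, so a step down in this assay is expected. For compound 4 the estimate is 1200 nM, with a range from 400 nM to 4000 nM. The expected step, a 6.4-fold lower number from compound 3 to compound 4 (0.81 log units; beyond the scatter), lies beyond the scatter.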

Compound 4, half-maximal inhibitory concentration: 500 nM
Compound 4: the middle estimate sits 2.4-fold (0.38 log units) above what was measured, and the stated range covers the measured number.
By their numbers in this assay, from the lowest: compounds 4 and 2 (each within the scatter of the next); then compound 1; then compound 3.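

In this assay, the aromatic carbon para to a large group proves sensitive to its substituent on this core: acetyl(methyl)amino in place of ethyl gives a 15-fold lower number from compound 3 to compound 4 (1.19 log units; beyond the scatter) and is a large change, while acetyl(methyl)amino in place of fluoro gives a 3.8-fold lower number from compound 1 to compound 4 (0.58 log units; beyond the scatter) and is a modest one. With acetyl(methyl)amino held fixed, pyridin-4-yl in place of pyridin-3-yl gives a 1.8-fold lower number from compound 2 to compound 4 (0.26 log units; within the scatter) and so does not separate the two pyridine attachments in this assay. No evidence at hand bears on the reason for these steps.

Open, as far as these compounds go, is how an amine, a carboxylic acid or a propyl chain at this position would read in this assay on this core. Also open is whether fluoro and ethyl keep their order on the pyridin-3-yl core, where only compound 2 is shown.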